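A few compounds are considered here, and "the series" means these few. Any claim that something is new, unique, unknown or untested is made for them only; others in the source may bear on it.

Measured compounds:
compound 1 `O=C(O)CC/C=C\CC1=CCC[C@@H]1NS(=O)(=O)c1ccc(F)cc1`, in a functional assay on a cell-free system (plasma) for inhibition of thromboxane A2 receptor (Homo sapiens), read by turbidimetry; on this read-out lower numbers stand for stronger inhibition and higher numbers for weaker inhibition: 1300 nM
compound 2 `O=C(O)CCC/C=C\CC1=CCC[C@@H]1NS(=O)(=O)c1ccc(F)cc1`, in this assay: 4400 nM; 4400 nM (2 entries)
compound 3 `O=C(O)COCCCC[C@H]1[C@H](F)CC[C@@H]1NS(=O)(=O)c1ccccc1`, in this assay: 1700 nM

Compound 1 gives the lower of the two single numbers, but compound 3 sits within the scatter of it, so the two cannot be ranked; compound 2 has two entries rather than one number. The account now turns to compound 4 `O=C(O)CC/C=C\CC1=CCC[C@@H]1NS(=O)(=O)c1ccc(Cl)c(Cl)c1`, which differs from compound 1 in one place: 3,4-dichlorophenyl in place of 4-fluorophenyl on a sulfonyl sulfur. Among the compounds with values here, no measured pair in this set shows such a change, so there is nothing to lean on. The step in this assay is expected to be small, toward a slightly lower number, and probably not beyond the scatter. Compound 4 is estimated at 700 nM, within 200 nM to 3000 nM, which means an expected step of a 1.9-fold lower number from compound 1 to compound 4 (0.27 log units; within the scatter).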

Compound 4, half-maximal inhibitory concentration: 1900 nM
For compound 4 the middle estimate is 2.7-fold (0.43 log units) below the measured one; measured number inside the range.
By their numbers in this assay, from the lowest: compounds 1, 3 and 4 (each within the scatter of the next).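

In a 1.5-fold higher number from compound 1 to compound 4 (0.16 log units; within the scatter), the step for 3,4-dichlorophenyl in place of 4-fluorophenyl on a sulfonyl sulfur lies within the scatter of this assay. Within the data shown here, this pair is the first to test this position, and it shows that this exchange of one aryl group for another gives no readable change on the core of compound 1. No evidence here bears on why.

On these data alone, it remains open whether a methyl, a naphthyl or a pyridyl group on the sulfonyl sulfur would shift the number. As far as these compounds go, whether 3,4-dichlorophenyl would behave the same way on the core of compound 2 is also open.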